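The source may report more compounds than this note shows. Statements on the series, on what has been measured and on what is new or still open speak of the compounds shown alone.

In a functional assay on MOLT-3 cells (Homo sapiens) (a lower number here means a stronger inhibitor, a higher number a weaker inhibitor), compound 1 (`CCCSC[C@H](NC(C)=O)C(=O)CCl`) gives 8000 nM and shares the high-number end of the series with compound 2 (`CCCCCSC[C@H](NC(C)=O)C(=O)CCl`), which gives 5400 nM. Compound 3 (`CCCCCCCSC[C@H](NC(C)=O)C(=O)CCl`) gives 2500 nM. Compound 4 (`CCCCCCCCSC[C@H](NC(C)=O)C(=O)CCl`) differs from compound 1 by pentyl in place of hydrogen on a saturated chain carbon, three bonds along the chain from a sulfur. Among the compounds with values here, three measured steps bear on this change: a 1.5-fold lower number from compound 1 to compound 2 (0.17 log units; within the scatter), a 3.2-fold lower number from compound 1 to compound 3 (0.51 log units; beyond the scatter) and a 2.2-fold lower number from compound 2 to compound 3 (0.33 log units; beyond the scatter). The closest is the butyl change, and pentyl goes slightly further, so a modest step to a lower number in this assay is expected, similar to or somewhat larger than that one. The expected step is a 4.2-fold lower number from compound 1 to compound 4 (0.62 log units; beyond the scatter). Compound 4 is estimated at 1900 nM, with an expected range of 900 nM to 3800 nM.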

Compound 4, half-maximal inhibitory concentration: 4100 nM
Beside the measured number, compound 4's estimate is 2.2-fold (0.33 log units) below it; the measured number lies above the stated range.
By their numbers in this assay, from the lowest: compounds 3, 4, 2 and 1 (each within the scatter of the next, the first and the last beyond it).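

In this assay the pentyl change gives a 2.0-fold lower number from compound 1 to compound 4 (0.29 log units; within the scatter) and so does not carry on from the butyl change, whose step from compound 1 lay beyond the scatter. Compound 4 cannot be separated from either neighbour with a shorter chain, with a 1.6-fold higher number from compound 3 to compound 4 (0.21 log units; within the scatter) and a 1.3-fold lower number from compound 2 to compound 4 (0.12 log units; within the scatter) as the two readings. The run of lower numbers through compounds 1, 2 and 3 therefore does not continue to compound 4, which goes against it.

From the compounds shown here alone, what happens with a longer chain such as decyl, or with a chain ending in an amine or a carboxylic acid, stays open. No evidence here accounts for this result.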